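The source may report more compounds than this note shows. Statements on the series, on what has been measured and on what is new or still open speak of the compounds shown alone.

The measured compounds:

Compound 1 `Cn1cc(C2=C(c3nn(CCCn4cccc4)c4ncccc34)C(=O)NC2=O)c2ccccc21` gives > 100000 nM in a functional assay on A549 cells (Homo sapiens) for antiproliferative activity, read by MTT assay, with a stated time of 48 h (on this read-out lower numbers stand for stronger inhibition and higher numbers for weaker inhibition), which is a limit of the assay and not a number.
Compound 2 `Cn1cc(C2=C(c3nn(CCCCn4ccnc4)c4ncccc34)C(=O)NC2=O)c2ccccc21` gives 2380 nM in this assay.
Compound 3 `Cn1cc(C2=C(c3nn(CCCn4cccc4)c4ncccc34)C(=O)N(c3ccccc3)C2=O)c2ccccc21` gives > 100000 nM in this assay, again a limit of the assay.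

Compound 1 and compound 2 differ in one place: (1H-imidazol-1-yl)methyl in place of 1H-pyrrol-1-yl on a saturated chain carbon, three bonds along the chain from an aromatic nitrogen. This change produces an at least 42-fold lower number from compound 1 to compound 2 (1.62 log units; beyond the scatter), although its true size is hidden, because of the limit of > 100000 nM in this assay, at which 2 of the 3 values shown sit.

Compound 1 and compound 3 differ in their cores: phenyl in place of hydrogen on an amide-type nitrogen in a ring. The step is a step that the two limits leave unreadable from compound 1 to compound 3, as both values sit at a limit.

Compound 4 `Cn1cc(C2=C(c3nn(CCCCn4ccnc4)c4ncccc34)C(=O)N(c3ccccc3)C2=O)c2ccccc21` has not yet been measured in this assay. It stands to compound 3 exactly as compound 2 stands to compound 1, with the same change: (1H-imidazol-1-yl)methyl in place of 1H-pyrrol-1-yl on a saturated chain carbon, three bonds along the chain from an aromatic nitrogen. The place is described in the same words in both pairs, so this is the same change, not merely the same kind. Since compound 3 starts at a limit, the step to compound 4 cannot be read from compound 3 alone. Compound 4 also differs from compound 2 only by the core change, whose effect is unreadable.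

The expectation for compound 4 is therefore a number between the value of compound 2 and the limit, namely 20000 nM, with a range from 3000 nM to 100000 nM, which is an estimated step of an at least 5.0-fold lower number from compound 3 to compound 4 (0.69 log units; beyond the scatter). This rests on compound 2 giving 2380 nM. It also allows for the uncertainty left by compound 3, whose value is only a limit of the assay.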

Compound 4, half-maximal inhibitory concentration: 21700 nM
Beside the measured number, compound 4's estimate is 1.1-fold (0.04 log units) below it; measured number inside the range.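

On the core that carries phenyl on the amide-type nitrogen, replacing 3-(1H-pyrrol-1-yl)propyl with 4-(1H-imidazol-1-yl)butyl gives an at least 4.6-fold lower number from compound 3 to compound 4 (0.66 log units; beyond the scatter) in this assay, so the direction of the change carries over to this second core, though its size cannot be compared: the same change on two cores in this assay, an at least 42-fold lower number (1.62 log units; beyond the scatter) from compound 1 to compound 2 and an at least 4.6-fold lower number (0.66 log units; beyond the scatter) from compound 3 to compound 4; the limit leaves it open whether they differ
Compound 3 gives > 100000 nM, which is a limit of the assay and not a number. With the imidazole chain in place on both compounds, phenyl in place of the amide hydrogen gives a 9.1-fold higher number from compound 2 to compound 4 (0.96 log units; beyond the scatter), so in this pair the change on the phenyl core does not reach the number seen on the core without phenyl.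

The change swaps the ring and lengthens the chain in a single step, so the compounds shown leave open which of the two matters; a 3-(1H-imidazol-1-yl)propyl or a 4-(1H-pyrrol-1-yl)butyl chain would pull the two apart. Also open, from the compounds shown here alone, is how the change would behave with a different group on the amide-type nitrogen, such as methyl or benzyl, or with a chain ending in an amine.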